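An Amino Group Added to a Weakly Cytotoxic Pair

A few compounds are considered here, and "the series" means these few. Any claim that something is new, unique, unknown or untested is made for them only; others in the source may bear on it.

Compound 1, `ClCc1ccc(Cn2cnc3c(Cl)ncnc32)cc1`, gives 63100 nM in a functional assay on HCT-15 cells (Homo sapiens) for cytotoxicity, read by sulforhodamine B assay, with a stated time of 48 h; on this read-out lower numbers stand for higher toxicity in this test and higher numbers for lower toxicity in this test.
Compound 2, `ClCc1cccc(Cn2cnc3c(Cl)nc(Cl)nc32)c1`, gives only a limit of > 100000 nM in this assay.

Among the measured compounds shown here, compound 1 holds the only number in this assay; the other result is a limit, (the limit of > 100000 nM in this assay, at which 1 of the 2 values shown sits). For the measured compounds named here, no pair of measured compounds differs in a single place, so no measured step is available to guide what a small change to this core does.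

Compound 3, `Nc1nc(Cl)c2ncn(Cc3ccc(CCl)cc3)c2n1`, differs from compound 1 by amino in place of hydrogen on an aromatic carbon. Going by the values given here, with no measured step to lean on, the step from compound 1 to compound 3 is expected to be small, not beyond the usual scatter in either direction, as a 1.1-fold lower number from compound 1 to compound 3 (0.02 log units; within the scatter) expresses. Compound 3 is therefore estimated to give 60000 nM in this assay, within a range of 20000 nM to 150000 nM, with a fair chance that only a limit is reported.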

Compound 3, concentration lethal to 50% of the cells: 67600 nM
Compound 3: the middle estimate sits 1.1-fold (0.05 log units) below what was measured; measured number inside the range.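

In this assay, among the compounds shown here, amino in place of hydrogen on an aromatic carbon gives a 1.1-fold higher number from compound 1 to compound 3 (0.03 log units; within the scatter), the first measured step on this core between compounds that differ in one place. The position between two ring nitrogen atoms therefore carries an amino group, and compound 1 and compound 3 cannot be told apart in this test. Compound 2 gives only a limit, and it differs from each of the other two compounds in more than one place, so it offers no step to set beside this one: the limit of > 100000 nM in this assay, at which 1 of the 3 values shown sits.

On these data alone, whether a larger group at the same position, such as a dimethylamino group or a morpholine ring, would leave the number equally untouched remains open. So does the part played by the chloromethyl group, which a plain methyl group in its place would test.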